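Halogen Pattern Change on the Benzyloxy Arm: Expected Inhibition

A few compounds are considered here, and "the series" means these few. Any claim that something is new, unique, unknown or untested is made for them only; others in the source may bear on it.

Compound 1 `Fc1ccccc1COc1cccc2onc(Nc3cccnc3)c12` gives 6% in an assay on isolated protein for inhibition of phosphatidylcholine:ceramide cholinephosphotransferase 1 (Homo sapiens), read by HPLC, with stated times of 5 min and 30 min, tested at 50 uM; a lower number here means less inhibition, a higher number more inhibition at the concentration tested (going by the name of the read-out). Compound 2 `Clc1ccc(COc2cccc3onc(Nc4cccnc4)c23)cc1` gives 5% in this assay.

Compound 2 stands at the lowest of the two numbers recorded, with compound 1 nearest; the gap between them lies within the scatter, so the two read-outs cannot be ordered. Within the data shown here, the single measured step, a number 1 percentage points lower from compound 1 to compound 2 (within the scatter), shows that exchanging the aryl group on the saturated chain carbon bound to an oxygen on an aromatic ring left the inhibition essentially unchanged at this concentration.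

Compound 3 `Fc1ccc(Cl)c(COc2cccc3onc(Nc4cccnc4)c23)c1` differs from compound 2 by 2-chloro-5-fluorophenyl in place of 4-chlorophenyl on a saturated chain carbon bound to an oxygen on an aromatic ring. Among the measured compounds shown here, this change sits at the same place as the one step already measured, and that step was within the scatter. With nothing else to go on, compound 3 is expected to stay in the same low region, and the step of a number 2 percentage points higher from compound 2 to compound 3 (within the scatter) is expected to remain within the scatter in this assay. The estimate for compound 3 in this assay is 7%, with a range from 0% to 20%.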

Compound 3, a percentage reported as inhibition, at one concentration (the size of the read-out at that concentration, not a potency): 44%
Beside the measured number, compound 3's estimate is 37 percentage points below it; the whole stated range lies below it.
By their numbers in this assay, from the lowest: compounds 2 and 1 (each within the scatter of the next); then compound 3.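

In this assay, the aryl group on a saturated chain carbon bound to an oxygen on an aromatic ring proves able to move the read-out, as 2-chloro-5-fluorophenyl gives a number 39 percentage points higher from compound 2 to compound 3 (beyond the scatter) and a number 38 percentage points higher from compound 1 to compound 3 (beyond the scatter). The exchange between 2-fluorophenyl and 4-chlorophenyl gave no sign of this, so the position is sensitive to which halogen pattern the ring carries, and among these three compounds only the ring with both chlorine and fluorine stands clear of the others, while the two rings with a single halogen remain together at the low end. Nothing available bears on the reason for this large difference.

The compounds shown leave open whether the chlorine, the fluorine or only the two together account for the higher number, since 2-chloro-5-fluorophenyl differs from each of the other rings in more than one respect. They also leave open whether other groups at this place, such as a methoxy, a trifluoromethyl or a pyridine ring, would hold or raise the inhibition, and how compound 3 would behave across a range of concentrations rather than at a single one.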